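A few compounds are considered here, and "the series" means these few. Any claim that something is new, unique, unknown or untested is made for them only; others in the source may bear on it.

Working notes on a triazole series carrying a phthalimide-type imide on the ring nitrogen, all tested in a functional assay on MKN-45 cells (Homo sapiens) for cytotoxicity, read by MTT assay, with a stated time of 48 h; a higher number here means a weaker inhibitor, a lower number a stronger inhibitor.

Compound 2 `CSc1nnc(C)n1N1C(=O)c2ccccc2C1=O` is the parent, bearing methyl on the ring carbon and methylsulfanyl. In this assay compound 2 reaches only the limit of the assay, > 200000 nM. Compound 1 `CCOC(=O)CSc1nnc(C)n1N1C(=O)c2ccccc2C1=O` carries the change (ethoxycarbonyl in place of hydrogen on a saturated chain carbon bound to a sulfur). In this assay compound 1 likewise gives only a limit, > 200000 nM. The step that the two limits leave unreadable from compound 2 to compound 1 is therefore not readable, because of the limit of > 200000 nM in this assay, at which 3 of the 3 values shown sit. Compound 3 `CCc1nnc(SC)n1N1C(=O)c2ccccc2C1=O` differs from compound 2 by methyl in place of hydrogen on a saturated chain carbon bound to an aromatic carbon. In this assay compound 3 again sits at a limit, > 200000 nM. The step that the two limits leave unreadable from compound 2 to compound 3 is equally unreadable for the same reason, since (the limit of > 200000 nM in this assay, at which 3 of the 3 values shown sit).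

Compound 4 `CCOC(=O)CSc1nnc(CC)n1N1C(=O)c2ccccc2C1=O` has not yet been measured. It differs from compound 3 by ethoxycarbonyl in place of hydrogen on a saturated chain carbon bound to a sulfur, the same change that turns compound 2 into compound 1, applied now on the ethyl-bearing core of compound 3. As compound 1 gives > 200000 nM in this assay, the same change is expected to leave compound 4 at the limit as well, an expected step that the limit leaves unreadable from compound 3 to compound 4. The estimate for compound 4 in this assay is 300000 nM, expected to fall between 150000 nM and 1000000 nM, most likely reported again only as a limit.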

Compound 4, half-maximal inhibitory concentration: > 200000 nM
Compound 4: a limit, no number; the forecaster's own chance of this, stated with the estimate: 85%; the middle value is on the limit's open side.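

In this assay compound 4 gives > 200000 nM, a limit and not a number. No step to compound 4 from compound 3 or compound 1 can be read: the limit of > 200000 nM in this assay, at which 4 of the 4 values shown sit.

The compounds shown leave open whether any change on the shared core yields a measurable value in this assay, and which group would do so.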